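This account rests on a few compounds, and the source may have more. Where it says the series, first, only, none or still open, it means among the compounds named here.

Measured compounds:
- compound 1, `CC(=O)N1N=C(c2ccc(-n3cncn3)cc2)CC1c1ccc(N(C)C)cc1`: -0.3%
- compound 2, `C=C(C)C(=O)N1N=C(c2ccc(-n3ccnc3)cc2)CC1c1ccc(N(C)C)cc1`: -3.7%

Both of these compounds were tested in a functional assay on NCI-H1975 cells (Homo sapiens) for inhibition, read by sulforhodamine B assay, tested at 10 uM; a lower number here means less inhibition, a higher number more inhibition at the concentration tested (going by the name of the read-out). In this assay compound 1 gives -0.3%, and compound 2 gives -3.7%. Compound 2 has the lowest of the two numbers, but its nearest neighbour, compound 1, lies within the usual scatter of it, so the two values cannot be told apart; both sit at essentially no inhibition at the concentration tested.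

Compound 3, `CN(C)c1ccc(C2CC(c3ccc(-n4ccnc4)cc3)=NN2S(=O)(=O)c2ccc(C#N)cc2)cc1`, has not yet been measured. It differs from compound 2 in one place: (4-cyanophenyl)sulfonyl in place of (1-methylethenyl)carbonyl on an amine nitrogen in a ring. The change is a (4-cyanophenyl)sulfonyl in place of a (1-methylethenyl)carbonyl on an amine nitrogen in a ring, which brings in a second aromatic ring and a larger group than the one that leaves.

Going by the values given here, no measured pair shows what this kind of exchange does in this assay, so the step from compound 2 to compound 3 can only be guessed. With no measured guidance, the expectation is a small rise, not clearly beyond the scatter, as the step of a number 9.7 percentage points higher from compound 2 to compound 3 (within the scatter) expresses. Compound 3 is therefore estimated to give about 6%, somewhere between -10% and 30%.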

Compound 3, a percentage reported as inhibition, at one concentration (the size of the read-out at that concentration, not a potency): 0.7%
Beside the measured number, compound 3's estimate is 5.3 percentage points above it; the measured number falls inside the stated range.
By their numbers in this assay, from the lowest: compounds 2, 1 and 3 (each within the scatter of the next).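

In this assay, putting (4-cyanophenyl)sulfonyl in place of (1-methylethenyl)carbonyl on the amine nitrogen of the five-membered non-aromatic ring gives a number 4.4 percentage points higher from compound 2 to compound 3 (within the scatter) and so no change that can be told from noise. This position therefore carries a larger group with a six-membered aromatic ring and a nitrile as readily as a group with no ring, and the reading stays at essentially no inhibition at the concentration tested. No other measurement here speaks to the reason for this flat result.

On these data alone, since both groups leave the reading at the same level, it remains open whether any group on this nitrogen can raise it, for instance a short chain ending in an amine or a sulfonyl group whose aromatic ring carries a carboxylic acid. The compounds also leave open whether changing the 4-(dimethylamino)phenyl group, which stays the same in this pair, would produce any measurable inhibition in these cells.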